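Removing the oxan-2-yl group from compound 3

A few compounds are considered here, and "the series" means these few. Any claim that something is new, unique, unknown or untested is made for them only; others in the source may bear on it.

In a functional assay on NCI-H1299 cells (Homo sapiens), read by flow cytometry (on this read-out lower numbers stand for an effect already at smaller amounts and higher numbers for an effect only at larger amounts of compound), compound 1 `N#Cc1ncc2nc1OCC/C=C\COc1ccc(Cl)cc1NC(=O)N2` gives > 10000 nM as a limit. Compound 2 `N#Cc1ncc2nc1OCC/C=C\COc1ccc(CCOC3CCCCO3)cc1NC(=O)N2` likewise gives > 10000 nM as a limit. Compound 3 `N#Cc1ncc2nc1OCC/C=C\COc1ccc(CCCOC3CCCCO3)cc1NC(=O)N2` gives > 10000 nM as a limit too, so no number of its own is known. The series thus rests on the limit of > 10000 nM in this assay, at which 3 of the 3 values shown sit, and on nothing finer. Within the data shown here, compound 4 `N#Cc1ncc2nc1OCC/C=C\COc1ccc(CCCO)cc1NC(=O)N2` has hydrogen in place of oxan-2-yl on an oxygen on a saturated carbon as its one change. Neither a step that the two limits leave unreadable from compound 2 to compound 3 nor a step that the two limits leave unreadable from compound 1 to compound 3 nor a step that the two limits leave unreadable from compound 1 to compound 2 gives a size to carry over. Only a modest move toward lower numbers is expected as an at least 1.4-fold lower number from compound 3 to compound 4 (0.15 log units; that floor lies within the scatter) and another limit reading remains likely. The estimate for compound 4 is 7000 nM (expected range 1500 nM to 10000 nM).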

Compound 4, half-maximal effective concentration: > 10000 nM
Compound 4 gave a limit, no number; the forecaster's own chance of this, stated with the estimate: 55%; at least 1.4-fold (0.15 log units) between middle value and limit.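

Among these compounds, compound 4 gives only a limit, as do compound 1, compound 2 and compound 3, so no step to compound 4 can be read. The compounds shown leave open whether swapping oxan-2-yl for hydrogen changes the effect at all, since everything rests on one limit: the limit of > 10000 nM in this assay, at which 4 of the 4 values shown sit.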